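The source may hold more compounds than are shown below. What is called first, only, known or untested is meant among the compounds shown, and "the series" means these compounds.

Measured compounds in a functional assay on Hs-578T cells (Homo sapiens) for antiproliferative activity, with a stated time of 48 h; a higher number here means a weaker inhibitor of growth, a lower number a stronger inhibitor of growth:
compound 1 , `Cc1cc(O)c(C2=NN(c3ccc(S(N)(=O)=O)cc3)C(c3ccccc3O)C2)cc1Cl`, gives 22500 nM
compound 2 , `Cc1cc(O)c(C2=NN(c3ccc(S(N)(=O)=O)cc3)C(c3ccccc3Cl)C2)cc1Cl`, gives 100000 nM
compound 3 , `Cc1cc(O)c(C2=NN(c3ccc(S(N)(=O)=O)cc3)C(/C=C/c3ccccc3)C2)cc1Cl`, gives 49700 nM

Compound 3 stands second highest of the three numbers. Its nearest neighbour is compound 2, at a 2.0-fold lower number from compound 2 to compound 3 (0.30 log units; within the scatter), a gap within the scatter; the widest separation is to compound 1, at a 2.2-fold higher number from compound 1 to compound 3 (0.34 log units; beyond the scatter), beyond the scatter.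

Compound 4 , `COc1ccc(C2CC(c3cc(Cl)c(C)cc3O)=NN2c2ccc(S(N)(=O)=O)cc2)cc1OC`, differs from compound 3 in one place: 3,4-dimethoxyphenyl in place of 2-phenylethenyl on a saturated ring carbon. For the measured compounds named here, three measured steps concern the substituent on the same saturated ring carbon: a 4.4-fold higher number from compound 1 to compound 2 (0.65 log units; beyond the scatter), a 2.2-fold higher number from compound 1 to compound 3 (0.34 log units; beyond the scatter) and a 2.0-fold lower number from compound 2 to compound 3 (0.30 log units; within the scatter). All are modest, and the 2-hydroxyphenyl of compound 1 gave the lowest number of the set. Whether a 3,4-dimethoxyphenyl lands nearer compound 1 or nearer compound 3 cannot be read from these three compounds alone. A modest step in this assay is therefore expected, more probably toward a lower number than a higher one, with wide uncertainty. Compound 4 is estimated at 30000 nM, in the range 10000 nM to 100000 nM, which would amount to a 1.7-fold lower number from compound 3 to compound 4 (0.22 log units; within the scatter).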

Compound 4, concentration for total growth inhibition: 34300 nM
Compound 4: middle estimate off by 1.1-fold (0.06 log units), on the low side; the range from low to high includes it.
By their numbers in this assay, from the lowest: compounds 1, 4, 3 and 2 (each within the scatter of the next, the first and the last beyond it).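

In this assay, the saturated ring carbon accepts 3,4-dimethoxyphenyl, which brings 2 hydrogen-bond acceptors, with no change beyond the scatter against 2-phenylethenyl, a 1.4-fold lower number from compound 3 to compound 4 (0.16 log units; within the scatter), or against the 2-hydroxyphenyl of compound 1, a 1.5-fold higher number from compound 1 to compound 4 (0.18 log units; within the scatter). Only the comparison with the 2-chlorophenyl of compound 2 is beyond the scatter, a 2.9-fold lower number from compound 2 to compound 4 (0.46 log units; beyond the scatter), so an aromatic group on this carbon does not by itself fix the number at that of compound 2. No measurement at hand accounts for these differences.

On these data alone, whether an aminomethyl group, a carboxylic acid or a longer alkyl chain on this carbon would bring the number below that of compound 1 stays open. Also open, as far as these compounds go, is how an unsubstituted phenyl or a phenyl carrying a single methoxy would compare with compound 4.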